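Sulfonyl aryl swap in the quinazoline piperazine series

The compounds below may be only part of what the source reports. "The series", "measured", "known", "first", "only" and "open" are said of these compounds alone.

Measured compounds:
Compound 1 `COc1cc2nc(N3CCN(C(=O)OCc4ccccc4)CC3)nc(N)c2cc1OC` — 63000 nM in a functional assay on PC-3 cells (Homo sapiens) for inhibition; a higher number here means a weaker inhibitor, a lower number a stronger inhibitor
Compound 2 `COc1cc2nc(N3CCN(C(=O)c4cccc5ccccc45)CC3)nc(N)c2cc1OC` — 59000 nM
Compound 3 `COc1cc2nc(N3CCN(S(=O)(=O)c4ccc(Cl)s4)CC3)nc(N)c2cc1OC` — 25000 nM

Compound 3 holds the lowest number of the three in this assay. One of its gaps is a 2.5-fold lower number from compound 1 to compound 3 (0.40 log units; beyond the scatter); the gap to compound 2 is of similar size, also beyond the scatter. Compound 1 and compound 2 sit together, the step between them being a 1.1-fold lower number from compound 1 to compound 2 (0.03 log units; within the scatter).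

The next compound, compound 4 `COc1cc2nc(N3CCN(S(=O)(=O)c4ccc(C(F)(F)F)cc4)CC3)nc(N)c2cc1OC`, keeps the sulfonyl linker of compound 3 and changes only the aromatic ring on it: 4-(trifluoromethyl)phenyl in place of 5-chlorothiophen-2-yl on a sulfonyl sulfur.

For the measured compounds named here, no measured step changes the aromatic group on a sulfonyl sulfur. The nearest comparison is the swap of the aromatic group on the carbonyl, a 1.1-fold lower number from compound 1 to compound 2 (0.03 log units; within the scatter), which stayed within the scatter. The step of a 2.5-fold lower number from compound 1 to compound 3 (0.40 log units; beyond the scatter) changed linker and ring at once and so does not separate the two effects. On this basis a step within the scatter is expected from compound 3 to compound 4 in this assay, no change at the digits printed from compound 3 to compound 4 (within the scatter). Compound 4 is therefore estimated at 25000 nM, with a range from 9000 nM to 70000 nM.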

Compound 4, half-maximal inhibitory concentration: 27000 nM
Compound 4: the middle estimate sits 1.1-fold (0.03 log units) below what was measured; the measured number falls inside the stated range.
By their numbers in this assay, from the lowest: compounds 3 and 4 (each within the scatter of the next); then compounds 2 and 1 (each within the scatter of the next).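

In this assay, 4-(trifluoromethyl)phenyl in place of 5-chlorothiophen-2-yl on a sulfonyl sulfur gives a 1.1-fold higher number from compound 3 to compound 4 (0.03 log units; within the scatter), the first read of an aromatic swap at this position with the sulfonyl linker held fixed. The read-out therefore does not separate these two groups, although they differ in ring size, hetero atom and heavy-atom count. No supporting data are available to explain this result.

How much of a 2.5-fold lower number from compound 1 to compound 3 (0.40 log units; beyond the scatter) belongs to the sulfonyl linker rather than the ring remains unsettled, as only two aromatic groups on the sulfonyl sulfur are shown. Also open, as far as these compounds go, is whether any aromatic ring is needed there, or whether an amine, a carboxylic acid or a longer alkyl chain at the same place would move the number beyond the scatter.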